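The source may hold more compounds than are shown below. What is called first, only, known or untested is meant among the compounds shown, and "the series" means these compounds.

Compound 2 `Cc1cn([C@H]2C[C@H](N=[N+]=[N-])[C@@H](COP(=O)(O)OP(=O)(O)OCc3ccc(OC(=O)c4ccc(C(F)(F)F)cc4)cc3)O2)c(=O)[nH]c1=O` and compound 1 `Cc1cn([C@H]2C=C[C@@H](COP(=O)(O)OP(=O)(O)OCc3ccc(OC(=O)c4ccc(C(F)(F)F)cc4)cc3)O2)c(=O)[nH]c1=O` have both been followed in an ADME assay on CCRF-CEM cells (Homo sapiens) for metabolic stability, read by HPLC, at 37 degrees C; a lower number here means that the compound disappears faster, a higher number that the compound lasts longer. In this assay compound 2 gives 3.83 h, the lower of the two numbers recorded so far. Compound 1 gives 11.5 h, which stands beyond the usual scatter above compound 2. Among the measured compounds shown here, no pair of measured compounds differs in only one place, so no single structural change has yet been tied to a shift in half-life.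

Compound 3 `CCCCCCCCCC(=O)Oc1ccc(COP(=O)(O)OP(=O)(O)OC[C@H]2O[C@@H](n3cc(C)c(=O)[nH]c3=O)C[C@@H]2N=[N+]=[N-])cc1` is the next compound to be measured. It differs from compound 2 in one place: nonyl in place of 4-(trifluoromethyl)phenyl on a carbonyl carbon. For the measured compounds named here, nothing measured so far shows what such an exchange does to half-life, so the expected step of a 1.1-fold lower number from compound 2 to compound 3 (0.04 log units; within the scatter) is put at none beyond the scatter, though with little confidence in either direction. On that basis the half-life of compound 3 is estimated at 3.5 h, within a range from 1.2 h to 10 h.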

Compound 3, half-life: 0.833 h
Estimate against measurement, compound 3: 4.2-fold (0.62 log units) above; measured number below the stated range.
By their numbers in this assay, from the lowest: compound 3; then compound 2; then compound 1.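

In this assay, putting nonyl in place of 4-(trifluoromethyl)phenyl on a carbonyl carbon gives a 4.6-fold lower number from compound 2 to compound 3 (0.66 log units; beyond the scatter). Among the compounds shown here, this is the first comparison here in which only one part of the molecule changes, and it shows that the group at this position can alter how long the compound lasts in these cells, even though the rest of the molecule stays the same. Nothing available explains why the half-life moves in this direction.

The change removes a ring and its fluorine atoms and brings in an open chain all at once, so the compounds shown cannot say which of these goes with the shorter half-life; a plain phenyl or a shorter chain such as butyl on this carbonyl carbon would help to separate them. On these data alone, it also remains open whether nonyl would bring a similar step on the core of compound 1.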